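Varying the Amine on the Amide Carbonyl

The source may hold more compounds than are shown below. What is called first, only, known or untested is meant among the compounds shown, and "the series" means these compounds.

Compound 1 `O=C(Nc1ccc(C(=O)N2CCCCc3sccc32)cc1OCCCC(=O)N1CCC(N2CCCCC2)CC1)c1ccccc1-c1ccccc1` — 20 nM
Compound 2 `CN1CCN(C(=O)CCCOc2cc(C(=O)N3CCCCc4sccc43)ccc2NC(=O)c2ccccc2-c2ccccc2)CC1` — 1 nM

In an assay on adrenal medulla for inhibition of Vasopressin V2 receptor (Rattus norvegicus), read by radioligand binding (a higher number here means a weaker inhibitor, a lower number a stronger inhibitor), compound 2 gives 1 nM, the lowest of the two numbers shown; its nearest neighbour is compound 1, which in this assay gives 20 nM. Within the data shown here, the one measured step bears directly on the amine carried by the carbonyl carbon: a 20-fold lower number from compound 1 to compound 2 (1.30 log units; beyond the scatter).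

Compound 3 `CCN(CC)C1CCN(C(=O)CCCOc2cc(C(=O)N3CCCCc4sccc43)ccc2NC(=O)c2ccccc2-c2ccccc2)CC1` is not yet measured. Its change from compound 2 is 4-(diethylamino)piperidin-1-yl in place of 4-methylpiperazin-1-yl on a carbonyl carbon. Among the measured compounds shown here, the group that enters is larger than 4-methylpiperazin-1-yl and closer in build to the 4-(piperidin-1-yl)piperidin-1-yl group of compound 1, so the measured step from compound 1 to compound 2 is the only guide, and it points toward a higher number on moving away from 4-methylpiperazin-1-yl. Compound 3 is therefore expected to land between the two measured values, with a step of a 5.0-fold higher number from compound 2 to compound 3 (0.70 log units; beyond the scatter), and an estimated value of 5 nM (range 1.5 nM to 20 nM).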

Compound 3, half-maximal inhibitory concentration: 6 nM
Compound 3: middle estimate off by 1.2-fold (0.08 log units), on the low side, and the stated range covers the measured number.
By their numbers in this assay, from the lowest: compound 2; then compound 3; then compound 1.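

In this assay, the change of the outer amine alone, diethylamino in place of piperidin-1-yl on a saturated ring carbon, gives a 3.3-fold lower number from compound 1 to compound 3 (0.52 log units; beyond the scatter) and so shows that the number responds to this outer group even when the piperidine amide stays the same. The other step, a 6.0-fold higher number from compound 2 to compound 3 (0.78 log units; beyond the scatter), shows that this gain does not carry the 4-(diethylamino)piperidin-1-yl group back to the level of the 4-methylpiperazin-1-yl group, which remains the lowest of the three amines shown. No measurement here accounts for either step.

On these data alone, it remains open whether the low number of compound 2 belongs to the piperazine ring itself or to its terminal methyl group. A 4-(dimethylamino)piperidin-1-yl group, an unsubstituted piperazin-1-yl group or a morpholin-4-yl group would help to separate these readings.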